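Benzyl ether substituent change in a TRPM8 inhibitor series

A few compounds are considered here, and "the series" means these few. Any claim that something is new, unique, unknown or untested is made for them only; others in the source may bear on it.

Compound 1 `CC(C)N(C(=O)c1ccccc1OCc1ccccc1)[C@@H]1CCC[C@H](N)C1`: 8780 nM
Compound 2 `N[C@H]1CCC[C@@H](N(CC2CC2)C(=O)c2ccccc2OCc2ccccc2)C1`: 593 nM
Compound 3 `CCN(C(=O)c1ccccc1OCc1cccc(Cl)c1)C1CCCC(N)C1`: 96.9 nM

All three compounds were tested in an assay on HEK293 cells for inhibition of transient receptor potential cation channel subfamily M member 8 (Homo sapiens), read by FLIPR and calcium flux; a lower number here means a stronger inhibitor, a higher number a weaker inhibitor. Compound 3 gives the lowest number of the three in this assay; its nearest neighbour is compound 2, and compound 1 lies furthest away. Among the compounds with values here, the one step that can be read from a single structural change runs a 15-fold lower number from compound 1 to compound 2 (1.17 log units; beyond the scatter), and it concerns the substituent on the amide-type nitrogen, not the benzyl ether.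

Compound 4 `CCN(C(=O)c1ccccc1OCc1ccccc1C#N)C1CCCC(N)C1` is the next compound. It differs from compound 3 in one place: 2-cyanophenyl in place of 3-chlorophenyl on a saturated chain carbon bound to an oxygen on an aromatic ring. Within the data shown here, no measured pair in this set isolates a change at that position, so the step from compound 3 to compound 4 has no direct precedent here. Compound 2 and compound 3 differ in several places at once, so their values cannot be split into a contribution from the ether substituent.

Among the measured compounds shown here, with no step to lean on, the expectation for compound 4 in this assay is a modest weakening, a 2.3-fold higher number from compound 3 to compound 4 (0.36 log units; beyond the scatter), with a wide band around it. The estimate for compound 4 is 220 nM, between 60 nM and 800 nM.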

Compound 4, half-maximal inhibitory concentration: 1850 nM
Beside the measured number, compound 4's estimate is 8.4-fold (0.92 log units) below it; measured number above the stated range.
By their numbers in this assay, from the lowest: compound 3; then compound 2; then compound 4; then compound 1.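

In this assay, within the data shown here, replacing 3-chlorobenzyl with 2-cyanobenzyl gives a 19-fold higher number from compound 3 to compound 4 (1.28 log units; beyond the scatter), the first reading of a single change at this place, on a saturated chain carbon bound to an oxygen on an aromatic ring. The earlier compounds shown here showed a large step only on the amide-type nitrogen, a 15-fold lower number from compound 1 to compound 2 (1.17 log units; beyond the scatter), so this result adds a second place where one change moves the number well beyond the scatter, and here the number rises rather than falls. With the shared core and the ethyl group unchanged, the step belongs to the exchange of these two aromatic groups alone, although nothing measured here explains the direction or size of the shift.

The step changes both the substituent and its printed location on the ring, so 2-chlorophenyl and 3-cyanophenyl would be needed to separate the nitrile from the location. The compounds shown also leave open how plain phenyl compares on the same ethyl amide, and therefore whether the chlorine of compound 3 or the nitrile of compound 4 accounts for more of the gap.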